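Isopropyl to Allyl on the Amine of Compound 1

The source may report more compounds than this note shows. Statements on the series, on what has been measured and on what is new or still open speak of the compounds shown alone.

For the measured compounds named here, compound 1 `CC(C)Nc1sc(C(=O)c2ccc(Cl)s2)c(N)c1C#N` is the only compound here with a numbered result: in an assay for inhibition of Maternal embryonic leucine zipper kinase (Homo sapiens), read by ADP-Glo, with a stated time of 0.5 h (a lower number here means a stronger inhibitor, a higher number a weaker inhibitor), compound 1 gives 192 nM. Compound 2 `CC(C)Nc1sc(C(=O)c2ccc(Cl)s2)cc1C#N` reaches only the limit of > 5000 nM in this assay, at which 1 of the 2 values shown sits, in this assay, and its value of > 5000 nM is a limit rather than a number. Going by the values given here, the one measured step, an at least 26-fold higher number from compound 1 to compound 2 (1.41 log units; beyond the scatter), concerns the amino group on the core, not the amine substituent. Compound 3 `C=CCNc1sc(C(=O)c2ccc(Cl)s2)c(N)c1C#N` differs from compound 1 by allyl in place of isopropyl on a nitrogen on an aromatic ring. Among the compounds with values here, no measured step bears on this change, so the step of a 1.3-fold higher number from compound 1 to compound 3 (0.11 log units; within the scatter) is expected to stay within the usual scatter. Compound 3 is expected to give 250 nM, with a range from 80 nM to 800 nM.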

Compound 3, half-maximal inhibitory concentration: 638 nM
Compound 3: the middle estimate sits 2.6-fold (0.41 log units) below what was measured; low and high end bracket the measured number.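

With allyl in place of isopropyl on the nitrogen, this assay shows a 3.3-fold higher number from compound 1 to compound 3 (0.52 log units; beyond the scatter) even though both groups hold 3 carbon atoms and no ring. This substituent on the amine therefore matters as well as the amino group on the core, and its count of heavy atoms alone does not settle the number. Nothing shown gives a reason for this step. Still open, going by these compounds, is how an n-propyl chain, a cyclopropyl ring or a longer chain on this nitrogen would compare with compound 1 and compound 3.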